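The source may hold more compounds than are shown below. What is called first, only, known or untested is meant among the compounds shown, and "the series" means these compounds.

Measured so far:
- Compound 1 `CN1CCN(c2ccc(C3=NN(S(=O)(=O)c4ccc(F)cc4)C(c4ccc(N(C)C)cc4)C3)cc2)CC1`: in a functional assay on HCC1806 cells (Homo sapiens) for inhibition, read by sulforhodamine B assay, tested at 10 uM (a higher number here means more inhibition at the concentration tested (going by the name of the read-out), a lower number less inhibition), compound 1 gives 92.3%.
- Compound 2 `CN1CCN(c2ccc(C3=NN(S(=O)(=O)c4ccc(Br)cc4)C(c4ccc(N(C)C)cc4)C3)cc2)CC1`: in this assay compound 2 gives 87.1%.
- Compound 3 `CN(C)c1ccc(C2CC(c3ccc(-n4cncn4)cc3)=NN2S(=O)(=O)c2ccc(F)cc2)cc1`: in this assay compound 3 gives 24.1%.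

Compound 4 `CN(C)c1ccc(C2CC(c3ccc(-n4cncn4)cc3)=NN2S(=O)(=O)c2ccc(Br)cc2)cc1` has not yet been measured. It is made from compound 3 by one change, (bromo in place of fluoro on an aromatic carbon). The very same change turns compound 1 into compound 2, (bromo in place of fluoro on an aromatic carbon), and there it gave a number 5.2 percentage points lower from compound 1 to compound 2 (within the scatter). The two cores on which this change is made are themselves different: the core of compound 3 carries 1H-1,2,4-triazol-1-yl in place of 4-methylpiperazin-1-yl on an aromatic carbon, and that difference gave a number 68.2 percentage points lower from compound 1 to compound 3 (beyond the scatter). The place of the halogen swap is described in the same words in both pairs, so it counts as the same change on two different cores. Because the same change gave a number 5.2 percentage points lower from compound 1 to compound 2 (within the scatter) on the core of compound 1, the expected step here is a number 3.1 percentage points lower from compound 3 to compound 4 (within the scatter), again within the scatter. Compound 4 is therefore estimated at 21%, with a likely range from 6% to 38%, pending the actual measurement.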

Compound 4, a percentage reported as inhibition, at one concentration (the size of the read-out at that concentration, not a potency): 26.3%
The estimate for compound 4 lay 5.3 percentage points below the measured number; measured number inside the range.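

In this assay, for the compounds shown here, bromo in place of fluoro on the triazolyl core gives a number 2.2 percentage points higher from compound 3 to compound 4 (within the scatter), and the halogen swap reads alike on both cores: the same change on two cores in this assay, a number 5.2 percentage points lower (within the scatter) from compound 1 to compound 2 and a number 2.2 percentage points higher (within the scatter) from compound 3 to compound 4, 7.4 percentage points apart, within the scatter of two such steps Putting 1H-1,2,4-triazol-1-yl in place of 4-methylpiperazin-1-yl on the bromo compounds gives a number 60.8 percentage points lower from compound 2 to compound 4 (beyond the scatter), so the large drop seen with fluoro recurs with bromo: the same change on two cores in this assay, a number 68.2 percentage points lower (beyond the scatter) from compound 1 to compound 3 and a number 60.8 percentage points lower (beyond the scatter) from compound 2 to compound 4, 7.4 percentage points apart, within the scatter of two such steps Across these four compounds the two changes therefore appear to act independently, but this rests on only two pairs per change at a single concentration, and it does not show why the swap from 4-methylpiperazin-1-yl to 1H-1,2,4-triazol-1-yl lowers the number or that the pattern would hold on other cores.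

The compounds shown leave open whether chloro or methoxy in the halogen's place would also leave the number within the scatter. They also leave open whether a morpholine ring or a simple dimethylamino group could stand in for 4-methylpiperazin-1-yl and keep the high numbers of compound 1 and compound 2.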